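The source may report more compounds than this note shows. Statements on the series, on what has been measured and on what is new or still open speak of the compounds shown alone.

Measured compounds in an assay on isolated protein for inhibition of phosphodiesterase 4A (Sus scrofa); a higher number here means a weaker inhibitor, a lower number a stronger inhibitor:
- compound 1 `COc1ccc(C(=O)Nc2ccccc2SC)cc1OC1CCCC1` gives 1200 nM
- compound 2 `COc1ccc(C(=O)Nc2ccccc2O)cc1OC1CCCC1` gives 1300 nM
- compound 3 `COc1ccc(C(=O)Nc2cccnc2)cc1OC1CCCC1` gives 550 nM

Compound 3 holds the lowest of the three numbers in this assay. The gap to the nearest one is a 2.2-fold lower number from compound 1 to compound 3 (0.34 log units; beyond the scatter) and to the furthest a 2.4-fold lower number from compound 2 to compound 3 (0.37 log units; beyond the scatter); both are modest but beyond the scatter. Between the two phenyl-bearing amides the step of a 1.1-fold higher number from compound 1 to compound 2 (0.03 log units; within the scatter) stays within the scatter, so the only movement seen in this small set comes from exchanging the aryl group on the amide-type nitrogen for pyridin-3-yl.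

Compound 4 `COc1ccc(C(=O)Nc2cnccn2)cc1OC1CCCC1` differs from compound 3 by pyrazin-2-yl in place of pyridin-3-yl on an amide-type nitrogen. Going by the values given here, no measured pair covers this particular exchange of one six-membered aromatic ring for another; the two steps that bear on it at all, a 2.2-fold lower number from compound 1 to compound 3 (0.34 log units; beyond the scatter) and a 2.4-fold lower number from compound 2 to compound 3 (0.37 log units; beyond the scatter), show that swapping the group on the amide-type nitrogen has so far moved the number only modestly. A step of similar or smaller size is therefore expected in this assay, with no clear direction, most likely within the scatter. For compound 4 the estimate is 700 nM, with a range from 250 nM to 2000 nM, corresponding to an expected step of a 1.3-fold higher number from compound 3 to compound 4 (0.10 log units; within the scatter).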

Compound 4, half-maximal inhibitory concentration: 250 nM
Estimate against measurement, compound 4: 2.8-fold (0.45 log units) above; measured number inside the range.
By their numbers in this assay, from the lowest: compound 4; then compound 3; then compounds 1 and 2 (each within the scatter of the next).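

In this assay the group on the amide-type nitrogen still has room to move the number, since even an exchange of one six-membered aromatic ring for another, pyrazin-2-yl in place of pyridin-3-yl, gives a 2.2-fold lower number from compound 3 to compound 4 (0.34 log units; beyond the scatter) and thus lies beyond the scatter. Measured against the two substituted phenyl amides, the same position now spans a 4.8-fold lower number from compound 1 to compound 4 (0.68 log units; beyond the scatter) and a 5.2-fold lower number from compound 2 to compound 4 (0.72 log units; beyond the scatter) as the widest steps in the set, and compound 4 lies beyond the scatter of all three other compounds. What separates compound 3 from compound 4 is a second ring nitrogen with no change in heavy-atom count, and no accompanying measurement offers any account of the step.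

One pair cannot show whether ring nitrogen count or ring nitrogen arrangement is what matters, and pyridin-2-yl, pyrimidin-5-yl or pyridazin-3-yl on the amide-type nitrogen would separate the two. Going by these compounds, the rest of the core is the same in all four compounds, so it remains open whether the step would hold with a longer alkoxy chain or a carboxylic acid elsewhere on the core.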